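Swapping the para group on the sulfonyl ring: a cytotoxicity forecast

A few compounds are considered here, and "the series" means these few. Any claim that something is new, unique, unknown or untested is made for them only; others in the source may bear on it.

Compound 1 `Cc1ccc(S(=O)(=O)N2C/C(=C\c3ccccc3F)C(=O)/C(=C/c3ccccc3F)C2)cc1`: 16700 nM
Compound 2 `O=C1/C(=C/c2ccccc2F)CN(S(=O)(=O)c2ccc(C(F)(F)F)cc2)C/C1=C\c1ccccc1F`: 16200 nM
Compound 3 `O=C1/C(=C/c2ccc(F)cc2)CN(S(=O)(=O)c2ccc(C(F)(F)F)cc2)C/C1=C\c1ccc(F)cc1`: 13500 nM

In an ADME assay on L02 cells (Homo sapiens) for cytotoxicity, read by MTT assay, with a stated time of 24 h (a lower number here means a stronger inhibitor, a higher number a weaker inhibitor), compound 3 gives a value that lies within the scatter of those of compound 1 and compound 2, so the three cannot be told apart. Compound 4 `N#Cc1ccc(S(=O)(=O)N2C/C(=C\c3ccc(F)cc3)C(=O)/C(=C/c3ccc(F)cc3)C2)cc1` differs from compound 3 by cyano in place of trifluoromethyl on an aromatic carbon. Among the measured compounds shown here, the only measured step that touches the same position, a 1.0-fold lower number from compound 1 to compound 2 (0.01 log units; within the scatter), changed a group on that aromatic carbon without moving the number beyond the scatter. One step is thin evidence, yet it points to little effect from a change at this position. For compound 4 the expected step is therefore a 1.0-fold higher number from compound 3 to compound 4 (0.02 log units; within the scatter), no more than scatter. Compound 4 is estimated at 14000 nM, in the range 6000 nM to 32000 nM.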

Compound 4, half-maximal inhibitory concentration: 14700 nM
Compound 4: the middle estimate sits 1.1-fold (0.02 log units) below what was measured, and the stated range covers the measured number.
By their numbers in this assay, from the lowest: compounds 3, 4, 2 and 1 (each within the scatter of the next).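

In this assay, cyano in place of trifluoromethyl gives a 1.1-fold higher number from compound 3 to compound 4 (0.04 log units; within the scatter) and so adds a second, different swap on this aromatic carbon that stays within the scatter. It also shows this on a compound whose other rings differ from those of compound 1 and compound 2. Nothing available explains why the reading stays level.

Still open, as far as these compounds go, is whether an amine, a carboxylic acid or a longer alkyl chain at this position would move the number beyond the scatter.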